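This account rests on a few compounds, and the source may have more. Where it says the series, first, only, none or still open, it means among the compounds named here.

Measured in an assay on HEK293 cells for displacement of a labelled ligand from 5-hydroxytryptamine receptor 7 (Homo sapiens), read by scintillation counting, with a stated time of 1 h; a lower number here means a stronger inhibitor, a higher number a weaker inhibitor:
Compound 1 `O=S(=O)(NCCCN1CCc2ccccc2C1)c1ccc2ccccc2c1` gives 80 nM in this assay.
Compound 2 `NCCN(CCCN1CCc2ccccc2C1)S(=O)(=O)c1ccccc1` gives 267 nM in this assay.
Compound 3 `COc1ccccc1N1CCN(CCCCNS(=O)(=O)c2cnc3ccccc3c2)CC1` gives 79 nM in this assay.

Compound 3 holds the lowest of the three numbers, but the gap to compound 1 lies within the usual scatter, so no order between those two can be read; only compound 2 sits clearly higher, beyond the scatter.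

Compound 4 `COc1ccccc1N1CCN(CCCCNS(=O)(=O)c2cccc3cccnc23)CC1` differs from compound 3 in one place: quinolin-8-yl in place of quinolin-3-yl on a sulfonyl sulfur. Within the data shown here, no measured pair shows this rearrangement, so no step size is known for it. With the same atoms joined differently, a step no larger than the scatter is expected, in either direction. Compound 4 is therefore estimated at 120 nM (range 40 nM to 400 nM), an expected step of a 1.5-fold higher number from compound 3 to compound 4 (0.18 log units; within the scatter).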

Compound 4, inhibition constant: 55 nM
The estimate for compound 4 lay 2.2-fold (0.34 log units) above the measured number; measured number inside the range.
By their numbers in this assay, from the lowest: compounds 4, 3 and 1 (each within the scatter of the next); then compound 2.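

In this assay, among these compounds, quinolin-8-yl in place of quinolin-3-yl on a sulfonyl sulfur gives a 1.4-fold lower number from compound 3 to compound 4 (0.16 log units; within the scatter) and so offers the first one-place comparison. At this position the two quinolines cannot be told apart, so moving the ring nitrogen of this group yields no readable step. No measurement at hand offers a reason for this result.

Open, as far as these compounds go, is whether an isoquinolin-5-yl group, or a quinoline carrying an amine, would produce a step beyond the scatter on this sulfonyl sulfur. Also open, from the compounds shown here alone, is how a longer chain to the sulfonamide nitrogen would read with either quinoline.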